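Changing one group on an aromatic ring

A few compounds are considered here, and "the series" means these few. Any claim that something is new, unique, unknown or untested is made for them only; others in the source may bear on it.

Values so far in a functional assay on RT-112 cells (Homo sapiens) for antiproliferative activity, read by MTT assay, with a stated time of 72 h; a higher number here means a weaker inhibitor of growth, a lower number a stronger inhibitor of growth
- compound 1 `COc1cc(Nc2ncnc3c(NC(=O)Nc4ccc([N+](=O)[O-])cc4)cccc23)cc(OC)c1` gives > 20000 nM (a limit, not a number)
- compound 2 `COc1cc(Nc2ncnc3c(NC(=O)Nc4ccc(C(F)(F)F)cc4)cccc23)cc(OC)c1` gives 3920 nM

In this assay, among the compounds with values here, compound 2 carries the only true number, and the other value is a limit. Compound 3 `CCOC(=O)c1ccc(NC(=O)Nc2cccc3c(Nc4cc(OC)cc(OC)c4)ncnc23)cc1` has ethoxycarbonyl in place of trifluoromethyl on an aromatic carbon, para to a large group ethoxycarbonyl in place of trifluoromethyl on an aromatic carbon here. Within the data shown here, the one measured step, an at least 5.1-fold lower number from compound 1 to compound 2 (0.70 log units; beyond the scatter), replaced nitro with trifluoromethyl at that place, so a change there can matter. Ethoxycarbonyl itself is untested, so a modest, uncertain rise in the number is expected. The estimated change is a 2.0-fold higher number from compound 2 to compound 3 (0.31 log units; beyond the scatter) in size. For compound 3 the expected value is 8000 nM (estimated range 2500 nM to 20000 nM).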

Compound 3, concentration for 50% growth inhibition: 317 nM
The estimate for compound 3 lay 25-fold (1.40 log units) above the measured number; measured number below the stated range.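

In this assay, this position proves able to carry far more than the first step showed: with ethoxycarbonyl, which has two hydrogen-bond acceptors where trifluoromethyl has none, the result is a 12-fold lower number from compound 2 to compound 3 (1.09 log units; beyond the scatter). Against nitro, the same group gives an at least 63-fold lower number from compound 1 to compound 3 (1.79 log units; beyond the scatter). Compound 1 carries a limit, not a number: the limit of > 20000 nM in this assay, at which 1 of the 3 values shown sits.

The compounds shown leave open which part of ethoxycarbonyl matters, the carbonyl or the ethyl chain. A carboxylic acid, a methyl ester or a primary amide at the same place would help to separate these.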